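Removing the Sulfur Group from a Phenoxyacetic Acid Alkyne

The compounds below may be only part of what the source reports. "The series", "measured", "known", "first", "only" and "open" are said of these compounds alone.

Compound 1, `C[S+]([O-])c1cccc(C#Cc2cc(Cl)ccc2OCC(=O)O)c1`: 3.2 nM
Compound 2, `CS(=O)(=O)c1cccc(C#Cc2cc(Cl)ccc2OCC(=O)O)c1`: 15 nM

Among the measured compounds shown here, in an assay on CHO cells for displacement of a labelled ligand from prostaglandin D2 receptor 2 (Homo sapiens), read by scintillation counting (a higher number here means a weaker inhibitor, a lower number a stronger inhibitor), compound 2 stands at the higher of the two numbers, with compound 1 as its only neighbour; the step of a 4.7-fold higher number from compound 1 to compound 2 (0.67 log units; beyond the scatter) lies between them. Compound 3, `O=C(O)COc1ccc(Cl)cc1C#Cc1ccccc1`, differs from compound 2 by hydrogen in place of methylsulfonyl on an aromatic carbon. For the measured compounds named here, no measured step removes this group altogether; the single related step, a 4.7-fold higher number from compound 1 to compound 2 (0.67 log units; beyond the scatter), shows that altering it moves the number beyond the scatter. For compound 3 a further rise, meaning weaker binding, is expected: a 6.7-fold higher number from compound 2 to compound 3 (0.82 log units; beyond the scatter). Compound 3 is therefore estimated at 100 nM, in a range from 20 nM to 500 nM.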

Compound 3, inhibition constant: 108 nM
The estimate for compound 3 lay 1.1-fold (0.03 log units) below the measured number; measured number inside the range.
By their numbers in this assay, from the lowest: compound 1; then compound 2; then compound 3.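

With hydrogen on this aromatic carbon, this assay records a 7.2-fold higher number from compound 2 to compound 3 (0.86 log units; beyond the scatter) and a 34-fold higher number from compound 1 to compound 3 (1.53 log units; beyond the scatter) as well. Both steps lie beyond the scatter, so in these three compounds either sulfur group gives stronger binding than hydrogen does. Removing the group altogether therefore costs more than changing one sulfur group into the other.

From the compounds shown here alone, whether sulfur itself is needed here stays open, since an amine or a nitrile at this place might serve as well. No measured evidence explains the rise in the number.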